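One more chain carbon: from compound 2 to compound 3

The source may report more compounds than this note shows. Statements on the series, on what has been measured and on what is new or still open speak of the compounds shown alone.

Compound 2 `CN(C)CCCCCCCOc1ccc2oc(-c3ccccc3)cc(=O)c2c1` gives 188 nM in an assay on isolated protein (Cavia porcellus) with Sigma non-opioid intracellular receptor 1 (Homo sapiens) as the target, read by radioligand binding (a lower number here means a stronger inhibitor, a higher number a weaker inhibitor), the lowest of the two numbers shown; compound 1 `CN(C)CCCCCCOc1ccc2oc(-c3ccccc3)cc(=O)c2c1` gives 335 nM, which lies within the scatter of it. Compound 3 `CN(C)CCCCCCCCOc1ccc2oc(-c3ccccc3)cc(=O)c2c1` is not yet measured and differs from compound 2 by (dimethylamino)methyl in place of dimethylamino on a saturated chain carbon, seven bonds along the chain from an oxygen on an aromatic ring. For the measured compounds named here, the only measured step that bears on this change is the same lengthening one bond nearer the oxygen, a 1.8-fold lower number from compound 1 to compound 2 (0.25 log units; within the scatter). For compound 3 a step of similar size, or none beyond the scatter, is therefore expected, a 1.3-fold lower number from compound 2 to compound 3 (0.10 log units; within the scatter). Compound 3 is estimated at 150 nM, between 60 nM and 400 nM.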

Compound 3, half-maximal inhibitory concentration: 143 nM
Beside the measured number, compound 3's estimate is 1.0-fold (0.02 log units) above it, within the range that was stated.
By their numbers in this assay, from the lowest: compounds 3, 2 and 1 (each within the scatter of the next, the first and the last beyond it).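

In this assay the one further chain carbon gives a 1.3-fold lower number from compound 2 to compound 3 (0.12 log units; within the scatter), so a single lengthening again stays within the scatter. Taken together, the two lengthenings, 2-(dimethylamino)ethyl in place of dimethylamino on a saturated chain carbon, give a 2.3-fold lower number from compound 1 to compound 3 (0.37 log units; beyond the scatter), the only step shown that passes the scatter, and only modestly. Nothing measured here bears on the reason for these steps.

Going by these compounds, whether a longer chain than that of compound 3 keeps the numbers falling or reverses them stays open. Also open, on these data alone, is how a piperidine in place of dimethylamino at the chain end would read on this chain.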